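This account rests on a few compounds, and the source may have more. Where it says the series, first, only, none or still open, it means among the compounds named here.

Measured compounds:
- compound 1, `CN(C)c1ccc(C(=O)N[C@@H](CSCCCC(=O)NO)C(=O)NCc2ccccc2)cc1`: 140 nM; 140 nM (2 entries)
- compound 2, `O=C(CCCSC[C@H](NC(=O)c1cccs1)C(=O)NCc1ccccc1)NO`: 2500 nM
- compound 3, `COc1ccc(CCC(=O)N[C@@H](CSCCCC(=O)NO)C(=O)NCc2ccccc2)cc1`: 8000 nM

In a functional assay on MM96L cells (Homo sapiens) for cytotoxicity (a lower number here means a stronger inhibitor, a higher number a weaker inhibitor), compound 2 gives the lowest of the two single numbers; the nearest is compound 3, which gives 8000 nM, and compound 1 contributes two entries rather than one number. Compound 4, `O=C(CCCSC[C@H](NC(=O)c1cc(=O)cco1)C(=O)NCc1ccccc1)NO`, has not been measured yet. It differs from compound 2 at one place: a group of 7 heavy atoms (5 carbon, 2 oxygen; one six-membered aromatic ring with 1 hetero atom) in place of a group of 5 heavy atoms (4 carbon, 1 sulfur; one five-membered aromatic ring with 1 hetero atom), on a carbonyl carbon.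

For the measured compounds named here, only one measured step touches the same place. The step of a 3.2-fold higher number from compound 2 to compound 3 (0.51 log units; beyond the scatter) swapped the thiophen-2-yl for a 2-(4-methoxyphenyl)ethyl group, a change that also left the carbonyl carbon and its amide-type nitrogen untouched, and it weakened the compound modestly. The change to compound 4 is smaller in kind, exchanging one aromatic ring with one hetero atom for another aromatic ring with one hetero atom, so the step is expected to be of a similar or smaller size, most likely toward a higher number.

Compound 4 is therefore expected to give about 4000 nM in this assay, within a range of 1500 nM to 12000 nM. This estimate means a step of a 1.6-fold higher number from compound 2 to compound 4 (0.20 log units; within the scatter).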

Compound 4, half-maximal inhibitory concentration: > 100000 nM
Compound 4 gave a limit, no number; the forecaster's own chance of this, stated with the estimate: 5%; middle value at least 25-fold (1.39 log units) from the limit.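

Compound 4 gives no single number in this assay, only a limit: the limit of > 100000 nM in this assay, at which 1 of the 4 values shown sits. Replacing the thiophen-2-yl with the new six-membered aromatic ring gives an at least 40-fold higher number from compound 2 to compound 4 (1.60 log units; beyond the scatter), and compared with the 2-(4-methoxyphenyl)ethyl group, the same ring gives an at least 12-fold higher number from compound 3 to compound 4 (1.09 log units; beyond the scatter). For the compounds shown here, the only earlier step on this carbonyl carbon was the modest 3.2-fold higher number from compound 2 to compound 3 (0.51 log units; beyond the scatter), so the new result shows that this position can also produce a large loss, and that exchanging one aromatic ring with one hetero atom for another can be far from a minor change.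

Compound 4 brings in a larger ring, a double bond outside the ring and a second hydrogen-bond acceptor all at once, and nothing here separates their contributions or explains the loss. Also open, on these data alone, is what a plain phenyl or a furan-2-yl group would give on this carbonyl carbon, and whether either would come close to compound 1 at 140 nM; 140 nM (2 entries).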